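The compounds below may be only part of what the source reports. "The series", "measured", "known", "first", "only" and "open" are said of these compounds alone.

The shared core is carried by compound 1 `Brc1ccc(-c2nc3ccccn3c2NC2CCCCC2)cc1`. Going by the values given here, in an assay on membranes from brain for displacement of a labelled ligand from adenosine receptor A1 (Rattus norvegicus) (a higher number here means a weaker inhibitor, a lower number a stronger inhibitor), compound 1 gives 3900 nM, the only plain number among the three measured compounds. Compound 2 `O=[N+]([O-])c1ccc(-c2nc3ccccn3c2NC2CCCCC2)cc1` reaches only a limit, > 100000 nM, in this assay. Compound 3 `Nc1c(-c2ccccc2)nc2ccccn12` likewise reaches only a limit, > 100000 nM, in this assay. Both of these limits sit on the same line, (the limit of > 100000 nM in this assay, at which 2 of the 3 values shown sit). Among the compounds with values here, the single measured step, an at least 25-fold higher number from compound 1 to compound 2 (1.40 log units; beyond the scatter), is a large loss of potency. Compound 4 `Fc1ccc(-c2nc3ccccn3c2NC2CCCCC2)cc1` differs from compound 1 in one place: fluoro in place of bromo on an aromatic carbon. Within the data shown here, no measured step swaps one halogen for another, so the nitro step serves only as a loose guide; it shows that a change at this place on the ring can matter a great deal. The step from compound 1 to compound 4 is expected to be a 2.6-fold higher number from compound 1 to compound 4 (0.41 log units; beyond the scatter), a modest weakening. Compound 4 is therefore estimated to give 10000 nM in this assay, with a range from 3000 nM to 40000 nM.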

Compound 4, inhibition constant: > 100000 nM
Compound 4: only a limit was reported; the forecaster's own chance of this, stated with the estimate: 15%; middle value at least 10-fold (1.00 log units) from the limit.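

The swap of one halogen for another at this place gives an at least 25-fold higher number from compound 1 to compound 4 (1.40 log units; beyond the scatter), so the large loss seen with nitro is not confined to that group. A change from 4-bromophenyl to 4-fluorophenyl, a single atom for a single atom, is enough to produce a loss of at least that printed size. In this assay compound 4 gives > 100000 nM, which is a limit and not a number, and the step between compound 2 and compound 4 cannot be read, as both sit at the same limit: the limit of > 100000 nM in this assay, at which 3 of the 4 values shown sit.

Among the compounds shown, bromo is the only group at this place that yields a plain number, and they do not tell why bromo differs from fluoro. From the compounds shown here alone, whether chloro, iodo, methyl or an amine at this place would give a plain number like that of compound 1 remains open.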